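This account rests on a few compounds, and the source may have more. Where it says the series, first, only, none or still open, it means among the compounds named here.

Measured so far in a functional assay on HT-29 cells (Homo sapiens) for cytotoxicity, read by MTT assay, with a stated time of 72 h; on this read-out higher numbers stand for lower toxicity in this test and lower numbers for higher toxicity in this test:
compound 1 `CCCOC(=O)Nc1ccc([Se]C#N)cc1` gives 75400 nM
compound 2 `N#C[Se]c1ccc(NC(=O)Oc2ccc(Cl)cc2)cc1` gives 68700 nM

Compound 2 shows the lower of the two numbers, but compound 1 sits within the scatter of it, so the two cannot be told apart. Compound 3 `N#C[Se]c1ccc(NC(=O)Oc2ccccc2)cc1` is not yet measured. It differs from compound 2 by hydrogen in place of chloro on an aromatic carbon. Among the measured compounds shown here, no measured pair shows how this kind of change moves the read-out, so no direction is assumed, and the change is expected to amount to a step of a 1.2-fold higher number from compound 2 to compound 3 (0.07 log units; within the scatter), within the scatter. Compound 3 is accordingly expected to give about 80000 nM in this assay, in a range from 35000 nM to 180000 nM.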

Compound 3, concentration lethal to 50% of the cells: 71700 nM
For compound 3 the middle estimate is 1.1-fold (0.05 log units) above the measured one, and the stated range covers the measured number.
By their numbers in this assay, from the lowest: compounds 2, 3 and 1 (each within the scatter of the next).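

With hydrogen in place of chloro on an aromatic carbon para to a large group, this assay shows a 1.0-fold higher number from compound 2 to compound 3 (0.02 log units; within the scatter) and so does not tell the two compounds apart. Phenyl in place of propyl gives a 1.1-fold lower number from compound 1 to compound 3 (0.02 log units; within the scatter) and likewise separates nothing, so neither swap registers in this test. Nothing measured here offers an explanation for these results.

On these data alone, whether an amine or a carboxylic acid in the place of that chloro would also leave the number within the scatter stays open. The same holds for a longer chain in the place of propyl.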